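The compounds below may be only part of what the source reports. "The series", "measured", "known", "first", "only" and "open" are said of these compounds alone.

Compound 1 `COc1cc(NCc2scnc2C)ccc1-c1cnco1`: 58500 nM
Compound 2 `COc1cc(/N=C/C=C/c2ccccc2)ccc1-c1cnco1`: > 100000 nM

In an ADME assay on Huh-7 cells (Homo sapiens) for cytotoxicity, read by MTT assay, with a stated time of 96 h (a lower number here means that less compound is tolerated, a higher number that more compound is tolerated), compound 1 gives 58500 nM, the only full number among the two results shown. For compound 2 the result is a limit of the assay, (the limit of > 100000 nM in this assay, at which 1 of the 2 values shown sits), rather than a number. Among the measured compounds shown here, compound 3 `COc1cc(NCc2ccsc2)ccc1-c1cnco1` differs from compound 1 by a single exchange: thiophen-3-yl in place of 4-methyl-1,3-thiazol-5-yl on a saturated chain carbon bound to a nitrogen on an aromatic ring No measured pair here differs in one place, so no measured step guides this exchange. The step of a 1.0-fold higher number from compound 1 to compound 3 (0.01 log units; within the scatter) is expected to be none beyond the usual scatter. Compound 3 is estimated at 60000 nM, within 25000 nM to 100000 nM.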

Compound 3, half-maximal cytotoxic concentration: 63100 nM
For compound 3 the middle estimate is 1.1-fold (0.02 log units) below the measured one, within the range that was stated.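

In this assay, thiophen-3-yl in place of 4-methyl-1,3-thiazol-5-yl on a saturated chain carbon bound to a nitrogen on an aromatic ring gives a 1.1-fold higher number from compound 1 to compound 3 (0.03 log units; within the scatter). This read-out therefore does not separate the two groups, although the entering group carries no ring nitrogen and 1 hydrogen-bond acceptor rather than 2. Nothing shown gives a cause for this result. Still open, as far as these compounds go, is whether an amine or a carboxylic acid on this chain carbon would move the value. The same holds for a phenyl or pyridine ring in place of thiophen-3-yl.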